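Heteroaryl swap on the terminal phenyl of compound 2

The source may hold more compounds than are shown below. What is called first, only, known or untested is meant among the compounds shown, and "the series" means these compounds.

Compound 2 `CCC(C)(C)Cc1c[nH]c(CCc2ccc(-c3cnccn3)cc2)n1` carries a pyrazin-2-yl group on the terminal phenyl ring of the shared core. Among the measured compounds shown here, in a functional assay on HEK293 cells for agonist activity at Bombesin receptor subtype-3 (Homo sapiens), read by luminescence and calcium flux, with a stated time of 10 min (a lower number here means that less compound is needed, a higher number that more compound is needed for the effect), compound 2 gives 100 nM, the lowest of the two numbers so far, though its nearest neighbour, compound 1 `CCC(C)(C)Cc1c[nH]c(CCc2ccc(-n3cccn3)cc2)n1`, gives 106 nM, and the two lie inside the usual scatter of each other. The next analogue, compound 3 `CCC(C)(C)Cc1c[nH]c(CCc2ccc(-c3cccc(C#N)n3)cc2)n1`, differs from compound 2 only at this position: 6-cyanopyridin-2-yl in place of pyrazin-2-yl on an aromatic carbon. For the measured compounds named here, one measured step bears on this kind of exchange, the swap of the six-membered heteroaryl for a five-membered one from compound 1 to compound 2, which gave a 1.1-fold lower number from compound 1 to compound 2 (0.03 log units; within the scatter). Since that aromatic exchange at the same position left the readout unchanged, no step beyond the scatter is expected here either. Compound 3 is therefore estimated at 90 nM in this assay, with a range of 35 nM to 250 nM, corresponding to an expected step of a 1.1-fold lower number from compound 2 to compound 3 (0.05 log units; within the scatter) from compound 2.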

Compound 3, half-maximal effective concentration: 95 nM
The estimate for compound 3 lay 1.1-fold (0.02 log units) below the measured number, and the stated range covers the measured number.
By their numbers in this assay, from the lowest: compounds 3, 2 and 1 (each within the scatter of the next).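

In this assay the exchange of pyrazin-2-yl for 6-cyanopyridin-2-yl gives a 1.1-fold lower number from compound 2 to compound 3 (0.02 log units; within the scatter) and the exchange of 1H-pyrazol-1-yl for the same group gives a 1.1-fold lower number from compound 1 to compound 3 (0.05 log units; within the scatter) with both steps inside the scatter. The position therefore accepts a group with one ring hetero atom and a nitrile, a triple bond outside the aromatic ring, with no readable difference from the two earlier heteroaryl groups. Why the three numbers sit together cannot be said, as no other data bear on this result.

From the compounds shown here alone, all three groups are single aromatic rings with no hydrogen-bond donors and no net charge, so it remains open how this position responds to a primary amine, a carboxylic acid or a saturated ring such as morpholine. Also open, going by these compounds, is any placement of these groups on the terminal phenyl other than the one printed, para to a large group.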